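The source may report more compounds than this note shows. Statements on the series, on what has been measured and on what is new or still open speak of the compounds shown alone.

Measured in a functional assay on HCT-116 cells (Homo sapiens) for antiproliferative activity, read by MTT assay, with a stated time of 48 h; on this read-out higher numbers stand for weaker inhibition and lower numbers for stronger inhibition:
- compound 1 `OC(/C=C/c1cccc(Cl)c1)c1nc2ccccc2[nH]1`: > 100000 nM (a limit)
- compound 2 `O=C(/C=C/c1ccccn1)c1nc2ccccc2[nH]1`: 60 nM
- compound 3 `O=C(CCc1cccc(Cl)c1)c1nc2ccccc2[nH]1`: > 100000 nM (a limit)

Compound 1 gives no true number in this assay. Compound 1 reads > 100000 nM, which is a limit of the assay. Compound 3 reads > 100000 nM, which is also a limit. Together they make up most of the small set: the limit of > 100000 nM in this assay, at which 2 of the 3 values shown sit. Only compound 2 gives a measured number, 60 nM, but it differs from compound 1 in more than one place, so it says little about a single swap.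

Compound 4 `COc1cccc(/C=C/C(O)c2nc3ccccc3[nH]2)c1` keeps the core of compound 1 and changes one group: methoxy in place of chloro on an aromatic carbon. This places methoxy in place of chloro on an aromatic carbon, meta to a large group. Among the compounds with values here, no measured pair here shows what this swap does. The best guide is therefore compound 1 itself, with its limit of > 100000 nM. On that basis, no step beyond the usual scatter is expected in this assay, in either direction, and compound 4 may well report only a limit too. The estimated change is a number no higher from compound 1 to compound 4 (the limit leaves the size open). Compound 4 is expected at 100000 nM, with an estimated range of 30000 nM to 200000 nM.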

Compound 4, half-maximal inhibitory concentration: > 100000 nM
Compound 4: a limit, no number (the forecaster's own chance of this, stated with the estimate: 75%); the middle value sits exactly at the limit.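

Compound 4, like compound 1, gives only a limit in this assay and not a true number, so no step between the two can be read: the limit of > 100000 nM in this assay, at which 3 of the 4 values shown sit.

The compounds shown leave open whether methoxy in place of chloro changes the inhibition at all, in either direction.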